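The source may hold more compounds than are shown below. What is called first, only, known or untested is meant among the compounds shown, and "the series" means these compounds.

The set comprises compound 1 `CNc1nc(O)c(Br)c(-c2ccccc2)n1`, compound 2 `Cn1c(-c2ccccc2)cc(=O)[nH]c1=O` and the as yet unmeasured compound 3 `Cn1c(-c2ccccc2)c(I)c(=O)[nH]c1=O`. In a functional assay on the whole organism for inhibition, with Rattus norvegicus as the target, at a dose of 100 mg/kg by the oral route (a higher number here means a stronger effect of the compound at the dose given, a lower number a weaker effect), compound 1 gives 82%. In this assay compound 2 gives 79%. Of the two numbers measured, the number for compound 2 lies within the usual scatter of the number for compound 1, so the two compounds cannot be told apart on these data, and neither can be called the stronger of the pair.

Compound 3 differs from compound 2 by iodo in place of hydrogen on an aromatic carbon. Among the measured compounds shown here, no pair of measured compounds that differ in a single place is available, so the data give no indication of how this change should bear on the read-out in this assay. Consequently the step from compound 2 to compound 3 is expected to be about a number 1 percentage points lower from compound 2 to compound 3 (within the scatter), which is a step not expected to go beyond the scatter in either direction. On that basis compound 3 is estimated to give 78% in this assay, with a range from 55% to 95%. The range is left wide on the low side because the data show nothing about the change and the measured numbers, such as 79% for compound 2, sit close to the top of the scale.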

Compound 3, a percentage reported as inhibition, in the whole organism at one dose (the size of the read-out at that dose, not a potency): 73%
Compound 3: middle estimate off by 5 percentage points, on the high side; low and high end bracket the measured number.
By their numbers in this assay, from the lowest: compounds 3, 2 and 1 (each within the scatter of the next).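

In this assay, among the compounds shown here, iodo in place of hydrogen on an aromatic carbon comes with a number 6 percentage points lower from compound 2 to compound 3 (within the scatter), which is the first reading of a single change in this set. The position, ortho to a group of 6 heavy atoms and two atoms from the ring nitrogen, therefore accepts this one iodine atom without the two compounds becoming distinguishable at this single dose. Nothing measured here offers a reason for this outcome.

Going by these compounds, it remains open whether a different kind of group at this position, such as an amine, a carboxylic acid or a longer chain like propyl, would also stay within the scatter of compound 2, or would move the read-out beyond it. The single oral dose also leaves open whether compound 2 and compound 3 would separate at other doses, and compound 1 differs from both in more than one place, so its steps to them cannot be read as the effect of any one change.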